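Cytotoxicity notes on acylating the amine of compound 1

This account rests on a few compounds, and the source may have more. Where it says the series, first, only, none or still open, it means among the compounds named here.

Measured so far:
compound 1 `Cc1c(C(=O)CSCCN)[n+]([O-])c2ccccc2[n+]1[O-]` gives "not determined" (no result reported)
compound 2 `Cc1ccc(SCC(=O)c2c(C)[n+]([O-])c3ccccc3[n+]2[O-])cc1` gives 50 ug/mL

In an ADME assay on Vero cells (Chlorocebus sabaeus) for cytotoxicity, read by MTT assay, with a stated time of 72 h (a higher number here means that more compound is tolerated, a lower number that less compound is tolerated), compound 1 gives "not determined" (no result reported) and so offers no number as a starting point. Compound 3 `COc1ccc(C(=O)NCCSCC(=O)c2c(C)[n+]([O-])c3ccccc3[n+]2[O-])cc1` differs from it by (4-methoxyphenyl)carbonyl in place of hydrogen on an amine nitrogen with (4-methoxyphenyl)carbonyl in place of hydrogen on an amine nitrogen. Among the compounds with values here, no measured step covers this change, so neither a size nor a direction can be expected from compound 1. Within the data shown here, the only anchor is compound 2 at 50 ug/mL and no departure beyond the scatter from it is expected. The estimated value for compound 3 is 40 ug/mL with an expected range from 12 ug/mL to 130 ug/mL in these notes.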

Compound 3, half-maximal cytotoxic concentration: > 100 ug/mL
Compound 3 was reported as a limit; the forecaster's own chance of this, stated with the estimate: 20%; middle value at least 2.5-fold (0.39 log units) away from the limit.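

Compound 1 has no number and compound 3 only a limit, so no step can be read between them. Going by these compounds, whether (4-methoxyphenyl)carbonyl on the amine nitrogen changes tolerance in this assay stays open.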